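A few compounds are considered here, and "the series" means these few. Any claim that something is new, unique, unknown or untested is made for them only; others in the source may bear on it.

The series shares the core seen in compound 1 `CC(O)(C(=O)Nc1ccc(S(=O)(=O)c2ccccc2Cl)cc1)C(F)(F)F`, compound 2 `Cc1cccc(S(=O)(=O)c2ccc(NC(=O)C(C)(O)C(F)(F)F)cc2)c1` and compound 3 `Cc1ccc(S(=O)(=O)c2ccc(NC(=O)C(C)(O)C(F)(F)F)cc2)cc1`, which differ only in the group on the sulfonyl sulfur. In a functional assay (Cavia porcellus) with sulfonylurea receptors; K-ATP channels (Homo sapiens) as the target (a higher number here means a weaker inhibitor, a lower number a stronger inhibitor), compound 1 gives 2300 nM. In this assay compound 2 gives 2200 nM, and the pair shows a 1.0-fold lower number from compound 1 to compound 2 (0.02 log units; within the scatter). For compound 3 this assay reports only a limit, > 30000 nM, not a number. This is the limit of > 30000 nM in this assay, at which 1 of the 3 values shown sits. Both steps onto compound 3 were large: an at least 13-fold higher number from compound 1 to compound 3 (1.11 log units; beyond the scatter) and an at least 13-fold higher number from compound 2 to compound 3 (1.13 log units; beyond the scatter). Compound 3 therefore stands at the weak end of the three, separated beyond the scatter from compound 1 and from compound 2.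

Compound 4 `CC(O)(C(=O)Nc1ccc(S(=O)(=O)c2cncs2)cc1)C(F)(F)F` is not yet measured. The change is 1,3-thiazol-5-yl in place of 4-methylphenyl on a sulfonyl sulfur. For the measured compounds named here, no measured step involves a five-membered aromatic ring with two hetero atoms, so the only bearing comes from the two large steps onto compound 3, which show that the 4-methylphenyl was the weak member in both comparisons made so far. Taking the departure from 4-methylphenyl as the relevant element, compound 4 is expected to move back toward the region of compound 1 and compound 2, though only partly, since the 1,3-thiazol-5-yl is unlike either ring tested. The expected step is an at least 5.0-fold lower number from compound 3 to compound 4 (0.69 log units; beyond the scatter). Compound 4 is estimated at 6000 nM, with a range of 1500 nM to 30000 nM.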

Compound 4, half-maximal inhibitory concentration: 7700 nM
Beside the measured number, compound 4's estimate is 1.3-fold (0.11 log units) below it; measured number inside the range.
By their numbers in this assay, from the lowest: compounds 2 and 1 (each within the scatter of the next); then compound 4. At a limit, above all of these: compound 3.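

The position on the sulfonyl sulfur now holds a third level: in this assay, the 1,3-thiazol-5-yl in place of 4-methylphenyl gives an at least 3.8-fold lower number from compound 3 to compound 4 (0.59 log units; beyond the scatter), so a five-membered aromatic ring with 2 hetero atoms returns a measurable number where the 4-methylphenyl gave none. The recovery is only partial, with a 3.5-fold higher number from compound 2 to compound 4 (0.54 log units; beyond the scatter) and a 3.3-fold higher number from compound 1 to compound 4 (0.52 log units; beyond the scatter), both printed as modest, so the 1,3-thiazol-5-yl matches neither the 3-methylphenyl nor the 2-chlorophenyl. The step from the 4-methylphenyl gives only a minimum size and not a full one, because compound 3 has a limit in place of a number: the limit of > 30000 nM in this assay, at which 1 of the 4 values shown sits.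

The compounds shown do not separate the ring size from the nitrogen and the sulfur of the 1,3-thiazol-5-yl, a question on which a thiophene or a pyridine ring on the sulfonyl sulfur would bear. They also leave open whether the loss with 4-methylphenyl is specific to the methyl group or extends to other groups in that ring, such as a 4-chlorophenyl or a 4-methoxyphenyl.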